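A few compounds are considered here, and "the series" means these few. Any claim that something is new, unique, unknown or untested is made for them only; others in the source may bear on it.

Going by the values given here, compound 1 `COc1cc2c(Nc3ccc(C#N)cc3)ncnc2cc1OCCCN1CCC(O)CC1` is the only member of this set with a number: in a functional assay on HepG2 cells (Homo sapiens) for antiproliferative activity, read by MTT assay, with a stated time of 72 h (on this read-out lower numbers stand for stronger inhibition and higher numbers for weaker inhibition), compound 1 gives 67900 nM. Compound 2 `COc1cc2c(Nc3ccc(C#N)cc3)ncnc2cc1OCCCN1CCCCC1CCO` reaches only a limit of the assay, > 100000 nM in this assay. Compound 3 `COc1cc2c(Nc3ccc(C#N)cc3)ncnc2cc1OCCCN1CCc2ccccc2C1` likewise reaches only a limit, > 100000 nM in this assay. The measured steps read an at least 1.4-fold higher number from compound 1 to compound 2 (0.16 log units; that floor lies within the scatter) and an at least 1.4-fold higher number from compound 1 to compound 3 (0.16 log units; that floor lies within the scatter); both end at the limit of > 100000 nM in this assay, at which 2 of the 3 values shown sit. Compound 4 `COc1cc2c(Nc3ccc(C#N)cc3)ncnc2cc1OCCCN1CCN(c2ccncc2)CC1` differs from compound 1 as follows: 4-(pyridin-4-yl)piperazin-1-yl in place of 4-hydroxypiperidin-1-yl on a saturated chain carbon, three bonds along the chain from an oxygen on an aromatic ring. Both measured exchanges of the 4-hydroxypiperidin-1-yl group carried the number to the limit, so compound 4 is expected to follow the same course, with an estimated step of a 1.5-fold higher number from compound 1 to compound 4 (0.17 log units; within the scatter). For compound 4 the estimate in this assay is 100000 nM, within 30000 nM to 300000 nM, with a fair chance that only a limit is reported.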

Compound 4, half-maximal inhibitory concentration: 12600 nM
Compound 4: middle estimate off by 7.9-fold (0.90 log units), on the high side; the measured number lies below the stated range.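

In this assay this chain carbon proves able to carry a change that lowers the number: 4-(pyridin-4-yl)piperazin-1-yl in place of 4-hydroxypiperidin-1-yl gives a 5.4-fold lower number from compound 1 to compound 4 (0.73 log units; beyond the scatter), whereas the two earlier exchanges gave only floors within the scatter. Against the other two groups the same exchange gives an at least 7.9-fold lower number from compound 3 to compound 4 (0.89 log units; beyond the scatter) and an at least 7.9-fold lower number from compound 2 to compound 4 (0.89 log units; beyond the scatter). Both of these steps are floors, not sizes: the limit of > 100000 nM in this assay, at which 2 of the 4 values shown sit.

Whether the step belongs to the piperazine or to the pyridin-4-yl ring stays open, as neither 4-phenylpiperazin-1-yl nor 4-methylpiperazin-1-yl stands among the compounds shown.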